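Alkene to Alkyne at the Chain End of Compound 2

A few compounds are considered here, and "the series" means these few. Any claim that something is new, unique, unknown or untested is made for them only; others in the source may bear on it.

Going by the values given here, compound 2 `C=CCCCCOc1cc(O)c(C(C)=O)cc1CC=C` stands lowest of the two numbers measured so far in an assay on isolated protein for inhibition of leukotriene B4 receptor 1 (Homo sapiens), tested at 10 uM; on this read-out lower numbers stand for less inhibition and higher numbers for more inhibition at the one concentration tested (going by the name of the read-out): compound 2 gives 73%, while compound 1 `C=CCc1cc(C(C)=O)c(O)cc1OCCCCCCCCC#N` gives 86%. Among the compounds with values here, the single measured step, a number 13 percentage points lower from compound 1 to compound 2 (beyond the scatter), concerns a change at the far end of the chain attached to the ring oxygen. Compound 3 `C#CCCCCOc1cc(O)c(C(C)=O)cc1CC=C` differs from compound 2 in that same region: ethynyl in place of vinyl on a saturated chain carbon, four bonds along the chain from an oxygen on an aromatic ring. Within the data shown here, this change has no direct precedent among the measured compounds; the one known step exchanged one end group for a different one, whereas here the group is kept and only the bond within it differs. The expected step of a number 3 percentage points lower from compound 2 to compound 3 (within the scatter) is therefore small, with no clear direction, and may well stay inside the scatter. For compound 3 the estimated value in this assay is 70%, within a range from 50% to 88%.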

Compound 3, a percentage reported as inhibition, at one concentration (the size of the read-out at that concentration, not a potency): 74%
The estimate for compound 3 lay 4 percentage points below the measured number, and the stated range covers the measured number.
By their numbers in this assay, from the lowest: compounds 2 and 3 (each within the scatter of the next); then compound 1.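

In this assay, exchanging the double bond of the vinyl end for the triple bond of ethynyl, on a saturated chain carbon, four bonds along the chain from an oxygen on an aromatic ring, gives a number 1 percentage points higher from compound 2 to compound 3 (within the scatter), so this exchange cannot be told apart from no change at all. Putting ethynyl in place of 4-cyanobutyl gives a number 12 percentage points lower from compound 1 to compound 3 (beyond the scatter), which shows that the drop first seen with vinyl also appears with a second short end group. Nothing measured here explains why these end groups behave as they do.

Going by these compounds, the step away from 4-cyanobutyl alters both the chain length and the end group, so the share of each stays unknown. A nitrile on a shorter chain, or a longer chain ending in ethynyl, would be needed to separate the two, and an amine or a carboxylic acid at the chain end remains an open question too.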